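The source may report more compounds than this note shows. Statements on the series, on what has been measured and on what is new or still open speak of the compounds shown alone.

Compound 1 `CC(C)(C)Cc1c(-c2cc(F)ccc2F)sc(N)c1C(=O)c1ccc(Cl)cc1` and compound 2 `CC(C)(C)Cc1c(-c2c(F)cccc2F)sc(N)c1C(=O)c1ccc(Cl)cc1` share one core and differ only in the difluorophenyl on an aromatic carbon. In an assay on CHO cells for displacement of a labelled ligand from adenosine receptor A3 (Homo sapiens), read by scintillation counting, tested at 10 uM (on this read-out higher numbers stand for more inhibition at the one concentration tested (going by the name of the read-out) and lower numbers for less inhibition), compound 1 gives 1%, and compound 2 gives 1%; the step of no change at the digits printed from compound 1 to compound 2 (within the scatter) shows nothing beyond the scatter, so compound 2 stands level with compound 1. Compound 3 `Cc1ccc(-c2sc(N)c(C(=O)c3ccc(Cl)cc3)c2CC(C)(C)C)cc1` carries 4-methylphenyl in place of 2,6-difluorophenyl on an aromatic carbon. Among the compounds with values here, the single measured step compared two difluorophenyl groups, not a 4-methylphenyl, so it bears only loosely on this change; with both neighbours so low, little movement is expected. For compound 3 the expected step is a number 4 percentage points higher from compound 2 to compound 3 (within the scatter), an estimate of 5% with a range from -8% to 25%.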

Compound 3, a percentage reported as inhibition, at one concentration (the size of the read-out at that concentration, not a potency): 1%
The estimate for compound 3 lay 4 percentage points above the measured number; low and high end bracket the measured number.
By their numbers in this assay, from the lowest: compounds 1, 2 and 3 (each within the scatter of the next).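

On the aromatic carbon next to the ring sulfur, 4-methylphenyl in place of 2,6-difluorophenyl shows no change at the digits printed from compound 2 to compound 3 (within the scatter) in this assay, and in place of 2,5-difluorophenyl it shows no change at the digits printed from compound 1 to compound 3 (within the scatter). The earlier pair only moved fluorine atoms around the ring, whereas this change removes both fluorines and adds a methyl group, and the read-out still does not separate the groups. Nothing available explains this flat result. Still open, from the compounds shown here alone, is whether an amine or carboxylic acid on this phenyl ring, or a longer chain in place of the neopentyl group, would give a reading beyond the scatter.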